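This account rests on a few compounds, and the source may have more. Where it says the series, first, only, none or still open, it means among the compounds named here.

Compound 3 `c1nc(NC2CC2)c2ncn(C3CC3)c2n1` stands lowest of the two numbers in a functional assay on the whole organism for antagonist activity, with Rattus norvegicus as the target (a higher number here means that more compound is needed for the effect, a lower number that less compound is needed), giving 4.5 mg/kg; compound 1 `CN(C)c1ncnc2c1ncn2C1CC1` gives 9 mg/kg, and the step of a 2.0-fold lower number from compound 1 to compound 3 (0.30 log units; within the scatter) comes with cyclopropylamino in place of dimethylamino on an aromatic carbon. Compound 2 `CC(C1CC1)n1cnc2c(NC3CC3)ncnc21` gives 2 mg/kg; 4.5 mg/kg; 12.5 mg/kg (3 entries) across repeated entries. Compound 4 `CCC(C)n1cnc2c(NC3CC3)ncnc21` differs from compound 3 by sec-butyl in place of cyclopropyl on an aromatic nitrogen. Among the measured compounds shown here, no measured step alters this group, so there is nothing to point in either direction, and the spread in the several entries of compound 2 in this assay, 2 mg/kg; 4.5 mg/kg; 12.5 mg/kg (3 entries) shows how far repeated numbers for one compound already lie apart; a change beyond the scatter is therefore not expected. Compound 4 is estimated at 5 mg/kg, between 1.5 mg/kg and 15 mg/kg, an expected step of a 1.1-fold higher number from compound 3 to compound 4 (0.05 log units; within the scatter).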

Compound 4, dose for half-maximal effect: 13.5 mg/kg
The estimate for compound 4 lay 2.7-fold (0.43 log units) below the measured number; the measured number falls inside the stated range.
By their numbers in this assay, from the lowest: compounds 3, 1 and 4 (each within the scatter of the next, the first and the last beyond it).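

Among the compounds shown here, this is the first measured change on the aromatic nitrogen, and in this assay it gives a 3.0-fold higher number from compound 3 to compound 4 (0.48 log units; beyond the scatter). So, on these numbers, swapping the cyclopropyl ring for the open sec-butyl group is not neutral, although the step is modest. It should be read with care, as repeated numbers for one compound can lie far apart: the several entries of compound 2 in this assay, 2 mg/kg; 4.5 mg/kg; 12.5 mg/kg (3 entries)

The compounds shown leave open whether the loss of the ring or the added carbon goes with this step, as the two groups differ in both. They also leave open how a cyclobutyl ring or a plain ethyl chain on this nitrogen would read.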